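From a Methylselanyl Group to a Cyanosulfanyl Group

The compounds below may be only part of what the source reports. "The series", "measured", "known", "first", "only" and "open" are said of these compounds alone.

For the measured compounds named here, in a functional assay on MCF7 cells (Homo sapiens) for cytotoxicity, read by MTT assay, with a stated time of 72 h (a lower number here means a stronger inhibitor of growth, a higher number a weaker inhibitor of growth), compound 2 `C[Se]c1nc2ccccc2s1` gives 7200 nM, the only plain number among the values shown. Compound 1 `[SeH]c1nc2ccccc2s1` gives > 50000 nM, which is a limit of the assay and not a number. Going by the values given here, the single measured step is therefore an at least 6.9-fold lower number from compound 1 to compound 2 (0.84 log units; beyond the scatter), and its size rests on (the limit of > 50000 nM in this assay, at which 1 of the 2 values shown sits).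

Compound 3 `N#CSc1nc2ccccc2s1` has not yet been measured. It differs from compound 2 in one place: a group of 3 heavy atoms (1 carbon, 1 nitrogen, 1 sulfur; no ring) in place of a group of 2 heavy atoms (1 carbon, 1 selenium; no ring), on an aromatic carbon. The cyanosulfanyl group sits on an aromatic carbon of a five-membered aromatic ring with 1 nitrogen and 1 sulfur, part of a fused or bridged system of two rings.

The measured step concerns a methyl in place of hydrogen on selenium, not the exchange of the whole group, so it bears only loosely on this change. Since compound 3, like compound 2, carries no hydrogen on the exchanged atom, and since an at least 6.9-fold lower number from compound 1 to compound 2 (0.84 log units; beyond the scatter) shows that capping mattered, compound 3 is expected to land nearer compound 2 than compound 1, with a step of a 2.1-fold higher number from compound 2 to compound 3 (0.32 log units; beyond the scatter) expected toward weaker inhibition. Compound 3 is estimated at 15000 nM, within a range of 3000 nM to 50000 nM.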

Compound 3, concentration for 50% growth inhibition: 40100 nM
For compound 3 the middle estimate is 2.7-fold (0.43 log units) below the measured one; the range from low to high includes it.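

In this assay, the result shows that a group with no hydrogen on the exchanged atom does not by itself keep the number close to that of compound 2: the cyanosulfanyl group in place of the methylselanyl group gives a 5.6-fold higher number from compound 2 to compound 3 (0.75 log units; beyond the scatter). The other new step is an at least 1.2-fold lower number from compound 1 to compound 3 (0.09 log units; that floor lies within the scatter), so this reading does not separate compound 3 from the selenium compound that carries the hydrogen, and capping alone therefore does not account for the earlier gain. How large that step really is stays unknown, as the value of compound 1 is a limit of the assay and not a number: the limit of > 50000 nM in this assay, at which 1 of the 3 values shown sits.

The compounds shown leave open which part of the exchange carries the step, as sulfur and the nitrile enter together in compound 3, and a methylsulfanyl group on the same aromatic carbon would set the two apart. For the compounds shown here, they also leave open how an amine or a longer chain on selenium would read at this position, so the methylselanyl group stands as the only capped group here with a number in the lower range.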